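From 2-bromobenzyl to 3-bromobenzyl: What to Expect

This account rests on a few compounds, and the source may have more. Where it says the series, first, only, none or still open, it means among the compounds named here.

Measured so far in an ADME assay on HEK293 cells (Homo sapiens) for cytotoxicity, read by MTT assay, with a stated time of 24 h; on this read-out lower numbers stand for stronger inhibition and higher numbers for weaker inhibition:
- compound 1 `CN(C)CCCNc1nc2cc([N+](=O)[O-])ccc2nc1NCc1ccccc1C(F)(F)F`: 24.7 ug/mL
- compound 2 `CN(C)CCCNc1nc2cc([N+](=O)[O-])ccc2nc1NCc1ccccc1Br`: 51.9 ug/mL

Of these two, compound 2 has the higher number at 51.9 ug/mL, which means weaker inhibition in this assay. Going by the values given here, its only neighbour is compound 1, with 24.7 ug/mL.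

The next compound is compound 3 `CN(C)CCCNc1nc2cc([N+](=O)[O-])ccc2nc1NCc1cccc(Br)c1`. It has 3-bromophenyl in place of 2-bromophenyl on a saturated chain carbon bound to a nitrogen on an aromatic ring. The atoms stay the same and only their arrangement changes.

Just one measured step offers any guide, a 2.1-fold higher number from compound 1 to compound 2 (0.32 log units; beyond the scatter). It was modest, and it exchanged trifluoromethyl for bromo, so it is a different kind of change. Among the compounds with values here, no measured pair shows what happens when the bromine changes place, so the direction is poorly supported. Only a small shift is expected, perhaps towards a lower number, and it may not clear the scatter. The expected change is a 1.3-fold lower number from compound 2 to compound 3 (0.11 log units; within the scatter). Compound 3 is estimated at 40 ug/mL, with an expected range of 18 ug/mL to 90 ug/mL.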

Compound 3, half-maximal inhibitory concentration: 3.66 ug/mL
The estimate for compound 3 lay 11-fold (1.04 log units) above the measured number; measured number outside the range, below it.
By their numbers in this assay, from the lowest: compound 3; then compound 1; then compound 2.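

The placement of the bromine on the phenyl ring matters far more in this assay than the two earlier compounds could show: with the same atoms, swapping 2-bromophenyl for 3-bromophenyl gives a 14-fold lower number from compound 2 to compound 3 (1.15 log units; beyond the scatter). This single rearrangement outweighs the earlier exchange of trifluoromethyl for bromo, and the change from 2-(trifluoromethyl)phenyl to 3-bromophenyl also gives a 6.7-fold lower number from compound 1 to compound 3 (0.83 log units; beyond the scatter), so compound 3 shows the strongest inhibition of the three. No measurement shown here explains why the placement has so large an effect.

Going by these compounds alone, with only one pair of bromine isomers, this shows what happens for 2-bromophenyl and 3-bromophenyl on this core, not a general rule for substituents on this ring. Going by these compounds, it remains open whether a chlorine or a nitrile in place of the bromine in 3-bromophenyl would keep the low number of compound 3, and whether a trifluoromethyl group would respond to the same change of placement as bromine does.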